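From Methoxycarbonyl to Acetyl: a Permeability Expectation

The source may report more compounds than this note shows. Statements on the series, on what has been measured and on what is new or still open speak of the compounds shown alone.

Of the compounds shown here, three sharing one core have been tested in an ADME assay for permeability, using PAMPA, at pH 7.4; a higher number here means that the compound crosses the layer faster, a lower number that the compound crosses the layer more slowly. Compound 1 `CCN(c1cc2oc(-c3ccc(F)cc3)c(C(=O)NC)c2cc1-c1cc(F)c(OC)c(C(=O)NC2(c3ncccn3)CC2)c1)S(C)(=O)=O` gives 659 nm/s. Compound 2 `CCN(c1cc2oc(-c3ccc(F)cc3)c(C(=O)NC)c2cc1-c1cc(F)c(F)c(C(=O)NC2(c3ncccn3)CC2)c1)S(C)(=O)=O` gives 731 nm/s. The step of a 1.1-fold higher number from compound 1 to compound 2 (0.05 log units; within the scatter), a fluoro in place of a methoxy on an aromatic carbon, stays within the scatter. Compound 3 `CCN(C(=O)OC)c1cc2oc(-c3ccc(F)cc3)c(C(=O)NC)c2cc1-c1ccc(OC)c(C(=O)NC2(c3ncccn3)CC2)c1` gives 660 nm/s, a number that sits within the scatter of both compound 1 and compound 2, so the three numbers cannot be told apart.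

Compound 4 `CCN(C(C)=O)c1cc2oc(-c3ccc(F)cc3)c(C(=O)NC)c2cc1-c1ccc(OC)c(C(=O)NC2(c3ncccn3)CC2)c1` has not yet been measured. It differs from compound 3 by methyl in place of methoxy on a carbonyl carbon, that is, a methyl in place of a methoxy on a carbonyl carbon. Among the compounds with values here, no measured step touches this position, and the only step at hand, a 1.1-fold higher number from compound 1 to compound 2 (0.05 log units; within the scatter), concerns an aromatic carbon and is itself within the scatter. With nothing pointing to a shift, compound 4 is expected to stay close to compound 3, the estimated step being a 1.0-fold lower number from compound 3 to compound 4 (0.01 log units; within the scatter). The estimate for compound 4 in this assay is 650 nm/s, with a range from 400 nm/s to 1000 nm/s.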

Compound 4, apparent permeability: 466 nm/s
Beside the measured number, compound 4's estimate is 1.4-fold (0.14 log units) above it; the range from low to high includes it.
By their numbers in this assay, from the lowest: compounds 4, 1, 3 and 2 (each within the scatter of the next).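

In this assay, within the data shown here, this is the first measured step at this position, and methyl in place of methoxy on a carbonyl carbon gives a 1.4-fold lower number from compound 3 to compound 4 (0.15 log units; within the scatter). The position, a carbonyl carbon whose other neighbour is an amide-type nitrogen, therefore accepts the swap of methoxycarbonyl for acetyl, with its loss of one oxygen and one hydrogen-bond acceptor, without a step that stands clear of the scatter. No supporting measurement bears on what lies behind the size of this step.

The compounds shown leave open how the number responds to a different kind of group on this carbonyl carbon, such as an amine, which would turn the carbamate into a urea, or a longer chain such as propyl. Also open, going by these compounds, is whether the same swap gives a similar step when the methoxy on the aromatic carbon is replaced by fluoro.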